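A few compounds are considered here, and "the series" means these few. Any claim that something is new, unique, unknown or untested is made for them only; others in the source may bear on it.

Of the compounds shown here, three sharing one core have been measured in an ADME assay on CCRF-HSB-2 cells (Homo sapiens) for cytotoxicity, with a stated time of 7 days; a higher number here means that more compound is tolerated, a lower number that less compound is tolerated. Compound 1 `CC(C)CSc1nc(N)nc2c1ncn2/C=C1/CC1(CO)CO` gives 60000 nM, and it is the only one of the three for which a number rather than a limit was recorded. Compound 2 `CCCCNc1nc(N)nc2c1ncn2/C=C1/CC1(CO)CO` reaches only a limit of the assay, > 20000 nM. Compound 3 `CN(C)c1nc(N)nc2c1ncn2/C=C1/CC1(CO)CO` likewise reaches only a limit, > 20000 nM. The steps a step that the limit leaves unreadable from compound 1 to compound 2 and a step that the limit leaves unreadable from compound 1 to compound 3 therefore cannot be sized, and the same holds for a step that the two limits leave unreadable from compound 2 to compound 3 because of the limit of > 20000 nM in this assay, at which 2 of the 3 values shown sit.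

Compound 4 `CC(C)Nc1nc(N)nc2c1ncn2/C=C1/CC1(CO)CO` has not yet been measured; it differs from compound 1 by isopropylamino in place of isobutylsulfanyl on an aromatic carbon. The two measured steps away from compound 1 also replace the isobutylsulfanyl group with an amino substituent on the same aromatic carbon, and both ended at the limit, so they give no readable size and no direction. The expected step of a 1.2-fold lower number from compound 1 to compound 4 (0.08 log units; within the scatter) is accordingly put at nothing beyond the scatter. Compound 4 is expected to give about 50000 nM in this assay, with a range from 15000 nM to 150000 nM, and a limit rather than a number is quite possible.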

Compound 4, half-maximal cytotoxic concentration: > 20000 nM
Compound 4 gave a limit, no number (the forecaster's own chance of this, stated with the estimate: 60%); the middle value lies beyond the limit too.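

In this assay compound 4 gives > 20000 nM, which is a limit and not a number. Its steps involving compound 1, compound 2 and compound 3 therefore cannot be read: the limit of > 20000 nM in this assay, at which 3 of the 4 values shown sit. The compounds shown leave open how far compound 2, compound 3 and compound 4 differ from compound 1 or from one another.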